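Ethylsulfonyl Replaces Isopropoxycarbonyl on the Ring Nitrogen

A few compounds are considered here, and "the series" means these few. Any claim that something is new, unique, unknown or untested is made for them only; others in the source may bear on it.

Compound 1 `CC(C)OC(=O)N1CCC(Oc2ncnc3c2CCN3c2ccc(S(C)(=O)=O)cc2F)CC1` gives 50.1 nM in a functional assay on CHO-K1 cells for agonist activity at Glucose-dependent insulinotropic receptor (Homo sapiens), read by a luciferase reporter, with a stated time of 5 h (a lower number here means that less compound is needed, a higher number that more compound is needed for the effect), the second highest of three numbers. Compound 2 `CC(C)(C)OC(=O)N1CCC(Oc2ncnc3c2CCN3c2ccc(S(C)(=O)=O)cc2F)CC1` gives 20 nM, and compound 3 `COCCOC(=O)N1CCC(Oc2ncnc3c2CCN3c2ccc(S(C)(=O)=O)cc2F)CC1` gives 316 nM. The step of a 2.5-fold lower number from compound 1 to compound 2 (0.40 log units; beyond the scatter) is modest, while a 6.3-fold higher number from compound 1 to compound 3 (0.80 log units; beyond the scatter) and a 16-fold higher number from compound 2 to compound 3 (1.20 log units; beyond the scatter) are larger. Compound 4 `CCS(=O)(=O)N1CCC(Oc2ncnc3c2CCN3c2ccc(S(C)(=O)=O)cc2F)CC1` differs from compound 1 by ethylsulfonyl in place of isopropoxycarbonyl on an amine nitrogen in a ring. Within the data shown here, none of the measured steps changes the group bound to the amine nitrogen in this way; they only vary the oxygen-bound chain, where 2-methoxyethyl raised the number and tert-butyl lowered it. The account therefore expects, without a close precedent, a step of a 2.0-fold higher number from compound 1 to compound 4 (0.30 log units; within the scatter), with wide uncertainty. Compound 4 is estimated at 100 nM, in a range from 25 nM to 400 nM.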

Compound 4, half-maximal effective concentration: 1580 nM
Compound 4: middle estimate off by 16-fold (1.20 log units), on the low side, outside the stated range (above it).
By their numbers in this assay, from the lowest: compound 2; then compound 1; then compound 3; then compound 4.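

Ethylsulfonyl on the amine nitrogen in a ring gives a 32-fold higher number from compound 1 to compound 4 (1.50 log units; beyond the scatter) and a 5.0-fold higher number from compound 3 to compound 4 (0.70 log units; beyond the scatter) and a 79-fold higher number from compound 2 to compound 4 (1.90 log units; beyond the scatter) in this series. Among these compounds, compound 4 thus stands above all three compounds with a carbonyl group on that nitrogen, so this position responds to the group bound to the nitrogen, and not only to the oxygen-bound chain that the earlier compounds varied. Nothing shown here accounts for the size of this step.

On these data alone, whether the loss extends to other sulfonyl groups, such as methylsulfonyl or phenylsulfonyl, remains open. So does the outcome with a urea or a plain acetyl on that nitrogen.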